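Amide Branching on a Potent Receptor Agonist Core

The compounds below may be only part of what the source reports. "The series", "measured", "known", "first", "only" and "open" are said of these compounds alone.

Compound 2 `Cc1nn(-c2ncnc3nc[nH]c23)c2c1C(NC(=O)c1ccccc1)CC(=O)N2` gives 3 nM in a functional assay on HEK293 cells for agonist activity at G-protein coupled receptor 39 (Homo sapiens), read by scintillation proximity assay and inositol phosphate accumulation, with a stated time of 75 min, in the presence of a further agent that is not named here (a lower number here means that less compound is needed, a higher number that more compound is needed for the effect), level with compound 1 `Cc1nn(-c2ncnc3nc[nH]c23)c2c1C(NC(=O)Cc1cccs1)CC(=O)N2`, which gives 3 nM. For the measured compounds named here, the only measured step, no change at the digits printed from compound 1 to compound 2 (within the scatter), exchanged one group on the amide carbonyl for another without moving the number beyond the scatter. Compound 3 `CCC(C(=O)NC1CC(=O)Nc2c1c(C)nn2-c1ncnc2nc[nH]c12)c1ccccc1` carries 1-phenylpropyl in place of phenyl on a carbonyl carbon. Going by the values given here, this change again touches only the group on the amide carbonyl, and the one comparable step showed no change, so only a modest step is expected, a 1.7-fold higher number from compound 2 to compound 3 (0.22 log units; within the scatter), with the direction uncertain. Compound 3 is expected to give 5 nM, between 1 nM and 30 nM.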

Compound 3, half-maximal effective concentration: 5 nM
Beside the measured number, compound 3's estimate shows no gap at the digits printed, within the range that was stated.
By their numbers in this assay, from the lowest: compounds 1, 2 and 3 (each within the scatter of the next).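

In this assay, the group on this carbonyl carbon can be enlarged from phenyl to the branched 1-phenylpropyl with only a 1.7-fold higher number from compound 2 to compound 3 (0.22 log units; within the scatter). Measured against the (thiophen-2-yl)methyl group, the same 1-phenylpropyl group gives a 1.7-fold higher number from compound 1 to compound 3 (0.22 log units; within the scatter), so all three groups at this place lie within the scatter of one another. Nothing available explains why the number holds.

Going by these compounds, all three groups contain an aromatic ring, so it remains open whether a ring-free group on this carbonyl carbon, such as a propyl chain or one ending in a carboxylic acid, would hold the number too.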